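The compounds below may be only part of what the source reports. "The series", "measured", "known", "first", "only" and "open" are said of these compounds alone.

Compound 2 `Clc1cccc(N2CCN(CCCCOc3ccc4c(c3)CCC4)CC2)c1` stands highest of the two compounds measured in a functional assay on the whole organism for inhibition, with Mus musculus as the target, at a dose of 25 mg/kg by the oral route (on this read-out lower numbers stand for less inhibition and higher numbers for more inhibition at the one dose given (going by the name of the read-out)), where compound 2 gives 37%. Among the measured compounds shown here, its only neighbour is compound 1 `Fc1cccc(N2CCN(CCCCOc3ccc4c(c3)CCC4)CC2)c1`, which in this assay gives 15%; the step of a number 22 percentage points higher from compound 1 to compound 2 (beyond the scatter) came with chloro in place of fluoro on an aromatic carbon. Compound 3 `Clc1ccc(N2CCN(CCCCOc3ccc4c(c3)CCC4)CC2)cc1` has not yet been measured. It differs from compound 2 in one place: 4-chlorophenyl in place of 3-chlorophenyl on an amine nitrogen in a ring. For the measured compounds named here, no measured step involves an exchange of 3-chlorophenyl for 4-chlorophenyl, so the one step on record, which swaps a halogen rather than the group that carries it, bears on this change only loosely and gives no direction to lean towards. The expectation is therefore a step of about a number 2 percentage points lower from compound 2 to compound 3 (within the scatter), that is, none beyond the scatter. Compound 3 is estimated to give 35% in this assay, with a range from 15% to 60%.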

Compound 3, a percentage reported as inhibition, in the whole organism at one dose (the size of the read-out at that dose, not a potency): 31%
The estimate for compound 3 lay 4 percentage points above the measured number, within the range that was stated.
By their numbers in this assay, from the lowest: compound 1; then compounds 3 and 2 (each within the scatter of the next).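

Exchanging 3-chlorophenyl for 4-chlorophenyl on the amine nitrogen in the ring comes with a number 6 percentage points lower from compound 2 to compound 3 (within the scatter) in this assay, so at this one dose the two chlorophenyl groups cannot be told apart. Exchanging 3-fluorophenyl for 4-chlorophenyl comes with a number 16 percentage points higher from compound 1 to compound 3 (beyond the scatter), so the higher numbers are not confined to the 3-chlorophenyl group: both chlorophenyl compounds stand clear of the 3-fluorophenyl compound. No measurement on hand accounts for these differences.

A 4-fluorophenyl group on the same nitrogen would be needed to show whether the fluoro compound's lower number holds wherever the halogen sits, and a plain phenyl group would show what the halogen adds at all. From the compounds shown here alone, whether a methoxy group or a nitrile on that ring would reach the level of the chlorophenyl compounds also stays open.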